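This account rests on a few compounds, and the source may have more. Where it says the series, first, only, none or still open, it means among the compounds named here.

Compound 1 `Oc1ccccc1/C=C/c1ccccc1O` and compound 3 `Oc1ccc(/C=C/c2cccc(O)c2)cc1` share the same atoms joined differently; the difference between the two cores is not broken down here. In a functional assay on MCF7 cells (Homo sapiens) for inhibition, read by MTT assay, with a stated time of 2 days (a lower number here means a stronger inhibitor, a higher number a weaker inhibitor), compound 1 gives 23 ug/mL, and compound 3 gives 23 ug/mL. Compound 2 `Nc1ccccc1/C=C/c1ccccc1O` carries amino in place of hydroxy on an aromatic carbon relative to compound 1, and in this assay compound 2 gives 39 ug/mL, a step of a 1.7-fold higher number from compound 1 to compound 2 (0.23 log units; within the scatter). Compound 4 `Nc1cccc(/C=C/c2ccc(O)cc2)c1` carries amino in place of hydroxy on an aromatic carbon relative to compound 3. The change is the same kind, but its place differs: ortho to the group of 9 heavy atoms in compound 2, meta to it in compound 4. Because the step of a 1.7-fold higher number from compound 1 to compound 2 (0.23 log units; within the scatter) was small, compound 4 is expected to move by about a 1.7-fold higher number from compound 3 to compound 4 (0.22 log units; within the scatter) from compound 3. In this assay compound 4 is therefore estimated at 38 ug/mL, with a likely range from 20 ug/mL to 70 ug/mL.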

Compound 4, half-maximal inhibitory concentration: 6 ug/mL
Estimate against measurement, compound 4: 6.3-fold (0.80 log units) above; measured number below the stated range.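

In this assay, amino in place of hydroxy on an aromatic carbon gives a 3.8-fold lower number from compound 3 to compound 4 (0.58 log units; beyond the scatter), so on this core the change goes with a lower number, unlike on the core of compound 1. The result of this change therefore does not carry over unchanged from one core to the other: the same change on two cores in this assay, a 1.7-fold higher number (0.23 log units; within the scatter) from compound 1 to compound 2 and a 3.8-fold lower number (0.58 log units; beyond the scatter) from compound 3 to compound 4, 6.5-fold (0.81 log units) apart, beyond the scatter of two such steps

These pairs do not show whether the gap comes from the different place of the change or from the rest of the core, and two pairs set no rule for the series. Still open, going by these compounds, is how another group at the place of the amino in compound 4, such as methoxy or a carboxylic acid, would compare with it.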